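Halophenyl triazole series: bromo analogue of compound 1

This account rests on a few compounds, and the source may have more. Where it says the series, first, only, none or still open, it means among the compounds named here.

Compound 1 `CC1(C)[C@H]2CC[C@]1(C)N(Cc1cn(-c3cccc(F)c3)nn1)C(=O)C2` gives 90 nM in a functional assay on LoVo cells (Homo sapiens) for inhibition, read by MTT assay, with a stated time of 24 h; on this read-out higher numbers stand for weaker inhibition and lower numbers for stronger inhibition. Compound 2 `CC1(C)[C@H]2CC[C@]1(C)N(Cc1cn(-c3ccccc3C#N)nn1)C(=O)C2` gives 140 nM, and compound 3 `CC1(C)[C@H]2CC[C@]1(C)N(Cc1cn(-c3cccc(Cl)c3)nn1)C(=O)C2` gives 70 nM. Compound 1 stands second highest of the three numbers; its nearest neighbour is compound 3, with a 1.3-fold lower number from compound 1 to compound 3 (0.11 log units; within the scatter), and its furthest is compound 2, with a 1.6-fold higher number from compound 1 to compound 2 (0.19 log units; within the scatter). The remaining pair shows a 2.0-fold lower number from compound 2 to compound 3 (0.30 log units; within the scatter). Within the data shown here, all three sit within the scatter of one another, so nothing separates them on the numbers so far.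

Compound 4 `CC1(C)[C@H]2CC[C@]1(C)N(Cc1cn(-c3ccc(Br)cc3)nn1)C(=O)C2` is not yet measured. It differs from compound 1 as follows: 4-bromophenyl in place of 3-fluorophenyl on an aromatic nitrogen. Bearing on this are the swap of chloro for fluoro, a 1.3-fold lower number from compound 1 to compound 3 (0.11 log units; within the scatter), and the two exchanges of the whole ring on the aromatic nitrogen, a 1.6-fold higher number from compound 1 to compound 2 (0.19 log units; within the scatter) and a 2.0-fold lower number from compound 2 to compound 3 (0.30 log units; within the scatter), none beyond the scatter. In this assay no step beyond the scatter is therefore expected for compound 4, with a 1.1-fold lower number from compound 1 to compound 4 (0.05 log units; within the scatter). Compound 4 is estimated at 80 nM, in a range from 35 nM to 200 nM.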

Compound 4, half-maximal inhibitory concentration: 60 nM
Compound 4: middle estimate off by 1.3-fold (0.12 log units), on the high side; the range from low to high includes it.
By their numbers in this assay, from the lowest: compounds 4, 3, 1 and 2 (each within the scatter of the next, the first and the last beyond it).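

In this assay, 4-bromophenyl on the aromatic nitrogen stays level with the two halophenyl groups already seen, with a 1.5-fold lower number from compound 1 to compound 4 (0.18 log units; within the scatter) and a 1.2-fold lower number from compound 3 to compound 4 (0.07 log units; within the scatter). Among these compounds, it also gives the only step so far that lies beyond the scatter, a modest one, with a 2.3-fold lower number from compound 2 to compound 4 (0.37 log units; beyond the scatter), whereas compound 2 and compound 3 remain within the scatter of each other. No measurement is available that bears on the reason for these steps.

The swap in compound 4 changes both the halogen and its place on the phenyl ring, and a 3-bromophenyl or 4-chlorophenyl partner would be needed to separate the two. Also open, from the compounds shown here alone, is how the aromatic nitrogen tolerates groups such as an aminophenyl, a carboxylic acid on the phenyl ring or a benzyl.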